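Swapping the aryl group on a shared core: cytotoxicity outlook

The source may hold more compounds than are shown below. What is called first, only, known or untested is meant among the compounds shown, and "the series" means these compounds.

Three compounds share one core and differ only in the group on a double-bonded chain carbon bound to a double-bonded ring carbon. In an ADME assay on HEK293 cells (Homo sapiens) for cytotoxicity, read by MTT assay, with a stated time of 48 h (a lower number here means a stronger inhibitor, a higher number a weaker inhibitor), compound 1 `CN(C)c1ccc(/C=C2/S/C(=N/c3ccccc3)N(Cc3ccncc3)C2=O)cc1` gives 122000 nM, the second highest of the three numbers; compound 2 `CCOc1cc(/C=C2/S/C(=N/c3ccccc3)N(Cc3ccncc3)C2=O)ccc1O` gives 46500 nM and compound 3 `O=C1/C(=C\c2ccccn2)S/C(=N/c2ccccc2)N1Cc1ccncc1` gives 161000 nM. The step of a 2.6-fold lower number from compound 1 to compound 2 (0.42 log units; beyond the scatter) is modest, while the step of a 1.3-fold higher number from compound 1 to compound 3 (0.12 log units; within the scatter) is within the scatter. Compound 4 `Cc1ccc(/C=C2/S/C(=N/c3ccccc3)N(Cc3ccncc3)C2=O)s1` carries another swap at the same place: 5-methylthiophen-2-yl in place of 4-(dimethylamino)phenyl on a double-bonded chain carbon bound to a double-bonded ring carbon. Because the measured steps of a 2.6-fold lower number from compound 1 to compound 2 (0.42 log units; beyond the scatter) and a 1.3-fold higher number from compound 1 to compound 3 (0.12 log units; within the scatter) were small, only a small change is expected for compound 4, a 1.2-fold lower number from compound 1 to compound 4 (0.09 log units; within the scatter). Compound 4 is therefore estimated at 100000 nM, ranging from 40000 nM to 250000 nM.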

Compound 4, half-maximal inhibitory concentration: 146000 nM
Compound 4: middle estimate off by 1.5-fold (0.16 log units), on the low side; measured number inside the range.
By their numbers in this assay, from the lowest: compound 2; then compounds 1, 4 and 3 (each within the scatter of the next).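

In this assay, the five-membered aromatic ring of 5-methylthiophen-2-yl gives a result that cannot be told apart from those of the six-membered 4-(dimethylamino)phenyl and pyridin-2-yl groups, with a 1.2-fold higher number from compound 1 to compound 4 (0.08 log units; within the scatter) and a 1.1-fold lower number from compound 3 to compound 4 (0.04 log units; within the scatter). Only 3-ethoxy-4-hydroxyphenyl stands apart from the new group, with a 3.1-fold higher number from compound 2 to compound 4 (0.50 log units; beyond the scatter). No evidence here explains these numbers.

On these data alone, it remains open whether the hydroxyl or the ethoxy part of that group accounts for this difference. A plain 4-hydroxyphenyl group at this place would help separate the two.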